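Stereocentre change from compound 3 to compound 4

The source may report more compounds than this note shows. Statements on the series, on what has been measured and on what is new or still open speak of the compounds shown alone.

In a functional assay on HL-60 cells (Homo sapiens) for antiproliferative activity, read by MTT assay (on this read-out higher numbers stand for weaker inhibition and lower numbers for stronger inhibition), compound 1 `O[C@@H]1[C@@H](OCc2ccccc2)[C@H](OCc2ccccc2)[C@@H](COCc2ccccc2)O[C@@H]1CC1CCCCC1` gives 17200 nM and compound 2 `C=C[C@@H]1O[C@H](COCc2ccccc2)[C@@H](OCc2ccccc2)[C@H](OCc2ccccc2)[C@H]1O` gives 11800 nM, two values within the usual scatter of each other. Compound 3 `CCCCCCCCCCCCCCCOC[C@H]1O[C@@H](CCC)[C@H](O)[C@@H](OCCCCCCCCCCCCCCC)[C@@H]1OCCCCCCCCCCCCCCC` is reported as "not active" (no number reported), so it has no single number to set beside them. Compound 4 `CCCCCCCCCCCCCCCOC[C@H]1O[C@H](CCC)[C@H](O)[C@@H](OCCCCCCCCCCCCCCC)[C@@H]1OCCCCCCCCCCCCCCC` is still to be measured in this assay. The structural step is small: the two compounds have the same atoms and bonds and differ only in configuration as drawn: 1 of 5 stereo elements differ; a stereocentre at a saturated ring carbon is drawn S in compound 3 and R in compound 4. Among the compounds with values here, no measured pair shows what such a change does. The expectation therefore rests on compound 3, reported as "not active" (no number reported): no large step is expected in this assay, and a report without a number is quite possible again. Compound 4 is expected at 50000 nM, with an estimated range from 18000 nM to 130000 nM.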

Compound 4, half-maximal inhibitory concentration: "not active" (no number reported)
Compound 4: no number reported; no gap can be computed for the estimate.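

In this assay, compound 3 and compound 4 are both reported as not active, without a number, so no step can be read between them. On these data alone, what inverting the saturated ring carbon stereocentre does to potency remains open.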